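Bromo in place of difluoromethoxy: notes on compound 3

A few compounds are considered here, and "the series" means these few. Any claim that something is new, unique, unknown or untested is made for them only; others in the source may bear on it.

Measured in a functional assay on M21 cells (Homo sapiens) for antiproliferative activity, read by sulforhodamine B assay, with a stated time of 48 h; a lower number here means a stronger inhibitor, a higher number a weaker inhibitor:
- compound 1 `CC(C)(C)c1ccc(NS(=O)(=O)c2ccc(N3CCNC3=O)cc2)cc1`: > 1000 nM
- compound 2 `O=C1NCCN1c1ccc(S(=O)(=O)Nc2ccc(OC(F)F)cc2)cc1`: 410 nM

The value of compound 1 is a limit, not a number. Among the compounds with values here, compound 2 stands at 410 nM, the only true number so far. Next comes compound 3 `O=C1NCCN1c1ccc(S(=O)(=O)Nc2ccc(Br)cc2)cc1`, with bromo in place of difluoromethoxy on an aromatic carbon: bromo in place of difluoromethoxy, para to a large group. Within the data shown here, one measured step bears on this place, an at least 2.4-fold lower number from compound 1 to compound 2 (0.38 log units; beyond the scatter), with difluoromethoxy in place of tert-butyl. On these data alone, that step rests on the limit of > 1000 nM in this assay, at which 1 of the 2 values shown sits, for compound 1, so its full size is unknown. In this assay no change beyond the scatter is expected, and the estimated step is a 1.3-fold higher number from compound 2 to compound 3 (0.13 log units; within the scatter). Compound 3 is estimated at 550 nM, with an expected range of 180 nM to 1500 nM.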

Compound 3, half-maximal inhibitory concentration: 130 nM
The estimate for compound 3 lay 4.2-fold (0.63 log units) above the measured number; measured number outside the range, below it.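

Bromo in place of difluoromethoxy on this aromatic carbon, para to a large group, gives a 3.2-fold lower number from compound 2 to compound 3 (0.50 log units; beyond the scatter), so a step beyond the scatter can be read here between two true numbers, not only against a limit. Bromo in place of tert-butyl gives an at least 7.6-fold lower number from compound 1 to compound 3 (0.88 log units; beyond the scatter). The value of compound 1 is a limit, so that step has only a minimum size: the limit of > 1000 nM in this assay, at which 1 of the 3 values shown sits.

Three groups at one carbon set no trend. On these data alone, whether chloro, an amine or a carboxylic acid at this carbon would follow bromo remains open.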